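The compounds below may be only part of what the source reports. "The series", "measured", "known", "first", "only" and "open" are said of these compounds alone.

Measured so far:
- compound 1, `Nc1cc(N)c2nc(-c3ccccc3)c(Sc3ccc(F)cc3)nc2c1`: 50100 nM
- compound 2, `Nc1cc(N)c2nc(-c3ccccc3)c(Oc3ccc(F)cc3)nc2c1`: 50100 nM

In a functional assay on SW-620 cells (Homo sapiens) for inhibition, read by sulforhodamine B assay, with a stated time of 48 h (a higher number here means a weaker inhibitor of growth, a lower number a stronger inhibitor of growth), compound 2 gives 50100 nM, and compound 1 gives 50100 nM, so compound 2 stands level with compound 1 at the digits shown. Among the compounds with values here, the only step recorded, no change at the digits printed from compound 1 to compound 2 (within the scatter), swaps the linking atom between the shared core and the fluorinated ring and leaves the growth-inhibiting concentration unchanged within the scatter.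

Compound 3, `Nc1cc(N)c2nc(-c3ccccc3)c(NCc3ccc(F)cc3)nc2c1`, has not yet been tested. It differs from compound 2 in one place: (4-fluorobenzyl)amino in place of 4-fluorophenoxy on an aromatic carbon. Within the data shown here, no measured step changes the linker to a nitrogen bearing a hydrogen, or lengthens it by a carbon, so nothing here speaks directly to that change. Among the measured compounds shown here, the one step that does exist, no change at the digits printed from compound 1 to compound 2 (within the scatter), shows that exchanging one linker for another at this position left the value where it was. On that basis the step of a 1.3-fold lower number from compound 2 to compound 3 (0.10 log units; within the scatter) is expected to be small, with no direction beyond the scatter. Compound 3 is therefore estimated at 40000 nM, within a range of 12000 nM to 60000 nM.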

Compound 3, concentration for total growth inhibition: 9550 nM
Beside the measured number, compound 3's estimate is 4.2-fold (0.62 log units) above it, outside the stated range (below it).
By their numbers in this assay, from the lowest: compound 3; then compounds 1 and 2 (each within the scatter of the next).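

In this assay, the aromatic carbon next to the ring nitrogen proves sensitive to the group it carries: (4-fluorobenzyl)amino in place of 4-fluorophenoxy gives a 5.2-fold lower number from compound 2 to compound 3 (0.72 log units; beyond the scatter), and the same group in place of (4-fluorophenyl)sulfanyl gives a 5.2-fold lower number from compound 1 to compound 3 (0.72 log units; beyond the scatter). The earlier exchange of sulfur for oxygen left the value unchanged, so that flat result does not extend to every change of linker at this position, and the new group differs from both earlier groups in two ways at once: its linking nitrogen adds a hydrogen-bond donor, and a carbon now stands between that nitrogen and the fluorinated ring. Nothing given here offers a measured reason for the shift in growth inhibition.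

These compounds cannot separate the contributions of the nitrogen and the extra carbon, whereas 4-fluorophenylamino would keep the nitrogen without the carbon, and 4-fluorobenzyloxy would keep the carbon without the nitrogen. Also open, as far as these compounds go, is whether a longer chain, such as 2-(4-fluorophenyl)ethylamino, would extend the shift or reverse it.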